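Swapping the Saturated Ring on a Fused Kinase Core

The source may report more compounds than this note shows. Statements on the series, on what has been measured and on what is new or still open speak of the compounds shown alone.

Of the compounds shown here, three have so far been tested in an assay on isolated protein for inhibition of protein kinase C zeta type (Homo sapiens), read by mobility shift assay, tested at 30 uM; on this read-out higher numbers stand for more inhibition at the one concentration tested (going by the name of the read-out) and lower numbers for less inhibition. Compound 1 `COc1cccc(-c2cc3[nH]nc(N)c3c(=O)[nH]2)c1` gives -1%, compound 2 `Cc1cc2[nH]nc(N)c2c(N2CCCCC2)n1` gives 43%, and compound 3 `Cc1cc2c(c(N)nn2C)c(N2CCCCC2)n1` gives -152%. Among these three numbers compound 3 stands lowest, with compound 1 as its nearest neighbour and compound 2 furthest away, both gaps well beyond the scatter. For the measured compounds named here, the only measured step between compounds that differ in one place is a number 195 percentage points lower from compound 2 to compound 3 (beyond the scatter), a change of a methyl in place of hydrogen on an aromatic nitrogen.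

Compound 4 `Cc1cc2c(c(N)nn2C)c(N2CC[C@H](O)C2)n1` keeps that methylated nitrogen of compound 3 and changes only the saturated ring: 3-hydroxypyrrolidin-1-yl in place of piperidin-1-yl on an aromatic carbon. Going by the values given here, no measured step touches this part of the molecule, so the methyl step gives no guidance on the direction of the new change; it only shows that numbers can move a long way. With nothing to anchor a direction, the expected value for compound 4 stays close to the starting point but carries a wide range. Compound 4 is estimated at -70%, expected to fall between -180% and 30%. That estimate corresponds to an expected step of a number 82 percentage points higher from compound 3 to compound 4 (beyond the scatter).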

Compound 4, a percentage reported as inhibition, at one concentration (the size of the read-out at that concentration, not a potency): 19%
Compound 4: middle estimate off by 89 percentage points, on the low side, within the range that was stated.
By their numbers in this assay, from the lowest: compound 3; then compound 1; then compound 4; then compound 2.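

In this assay, for the compounds shown here, the saturated ring on the aromatic carbon proves to be a second place where the number can move a long way, with a number 171 percentage points higher from compound 3 to compound 4 (beyond the scatter), a large step at a position that no earlier step had touched. The change is a bundle rather than a single edit: a six-membered ring becomes a five-membered one, an oxygen enters as a hydroxyl, and a defined stereocentre appears, so this one step cannot be divided among those three differences. Nothing available here bears on why the number rose.

The compounds shown leave open which part of the bundle carries the step, something that a plain pyrrolidine ring without the hydroxyl, a piperidine ring carrying a hydroxyl, or the opposite stereocentre of 3-hydroxypyrrolidin-1-yl could separate. Going by these compounds, it also remains open whether the hydroxyl itself can be exchanged, for example for an amine or a methoxy group, and whether 3-hydroxypyrrolidin-1-yl would give a similar step on a core that keeps hydrogen on the aromatic nitrogen.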